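This account rests on a few compounds, and the source may have more. Where it says the series, first, only, none or still open, it means among the compounds named here.

Working notes on a series sharing one core, read in a physicochemical assay for solubility, in phosphate buffer, at pH 7.4; a lower number here means a less soluble compound, a higher number a more soluble compound: compound 1 `CCOC(=O)c1c(-c2ccccc2C)[nH]c2cc(OC)ccc2c1=O`, compound 2 `CCOC(=O)c1c(-c2ccccc2)[nH]c2cc(OC)ccc2c1=O`, compound 3 `CCOC(=O)c1c(-c2ccccc2Cl)[nH]c2cc(OC)ccc2c1=O` and the unmeasured compound 4 `CCOC(=O)c1c(-c2cccc(C(F)(F)F)c2)[nH]c2cc(OC)ccc2c1=O`. Compound 2 gives > 100000 nM, a limit of the assay and not a number. Compound 1 gives > 100000 nM, also a limit. Compound 3 gives a true number, 28000 nM.

The change to compound 4 is trifluoromethyl in place of hydrogen on an aromatic carbon. The closest measured change is chloro in place of hydrogen on an aromatic carbon, an at least 3.5-fold lower number from compound 2 to compound 3 (0.55 log units; beyond the scatter). Chloro in place of methyl on an aromatic carbon gives an at least 3.5-fold lower number from compound 1 to compound 3 (0.55 log units; beyond the scatter). The remaining measured change gives no size: a step that the two limits leave unreadable from compound 1 to compound 2.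

On the basis of an at least 3.5-fold lower number from compound 2 to compound 3 (0.55 log units; beyond the scatter), a step of at least modest size towards a lower number is expected in this assay, although a different group enters here. The estimated step is an at least 4.0-fold lower number from compound 2 to compound 4 (0.60 log units; beyond the scatter). For compound 4 the estimated value is 25000 nM, with an expected range of 6000 nM to 90000 nM.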

Compound 4, solubility: 19000 nM
Compound 4: the middle estimate sits 1.3-fold (0.12 log units) above what was measured, within the range that was stated.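

In this assay, trifluoromethyl in place of hydrogen on an aromatic carbon, meta to a large group, gives an at least 5.2-fold lower number from compound 2 to compound 4 (0.72 log units; beyond the scatter). A readable step towards a lower number from compound 2 is therefore no longer confined to chloro, and this position also responds to substitution. The step remains only a bound because compound 2 sits at a limit: the limit of > 100000 nM in this assay, at which 2 of the 4 values shown sit.

As far as these compounds go, the full size of the step stays open. Also open, from the compounds shown here alone, is whether an amine or a carboxylic acid at this position would give a lower number or a higher one.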